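A few compounds are considered here, and "the series" means these few. Any claim that something is new, unique, unknown or untested is made for them only; others in the source may bear on it.

Compound 1 `Cc1cc(C)cc(Cc2ccc3c(NCCCNCc4ccco4)ccnc3c2)c1` is measured in a physicochemical assay for acid dissociation, where compound 1 gives 9.47. Compound 2 `COc1cccc(CNCCCNc2ccnc3cc(Cc4cc(C)cc(C)c4)ccc23)c1O` differs from compound 1 only at the far end of the chain, by 2-hydroxy-3-methoxyphenyl in place of furan-2-yl on a saturated chain carbon bound to an amine nitrogen; in this assay compound 2 gives 9.47, so no change at the digits printed from compound 1 to compound 2 (within the scatter). Compound 3 `COc1cccc(Oc2ccc3c(NCCCNCc4ccco4)ccnc3c2)c1` differs from compound 1 on the other side of the molecule, by 3-methoxyphenoxy in place of 3,5-dimethylbenzyl on an aromatic carbon; in this assay compound 3 gives 9.28, and a number 0.19 log units lower from compound 1 to compound 3 (within the scatter).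

Compound 4 `COc1cccc(Oc2ccc3c(NCCCNCc4cccc(OC)c4O)ccnc3c2)c1` has not yet been measured. It stands to compound 3 exactly as compound 2 stands to compound 1: the same change, (2-hydroxy-3-methoxyphenyl in place of furan-2-yl on a saturated chain carbon bound to an amine nitrogen), at the same place. The cores of the two pairs differ by 3-methoxyphenoxy in place of 3,5-dimethylbenzyl on an aromatic carbon, a change that itself left the read-out within the scatter.

Because the first occurrence of this change gave no change at the digits printed from compound 1 to compound 2 (within the scatter), the step from compound 3 to compound 4 is expected to be about as small, no change at the digits printed from compound 3 to compound 4 (within the scatter). Compound 4 is therefore estimated at 9.28 in this assay, with a likely range from 8.95 to 9.6.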

Compound 4, acid dissociation constant: 9.28
For compound 4 middle estimate and measured number coincide at the digits printed; the measured number falls inside the stated range.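

In this assay, putting 2-hydroxy-3-methoxyphenyl in place of furan-2-yl on the core of compound 3 gives no change at the digits printed from compound 3 to compound 4 (within the scatter), just as the same swap on the core of compound 1 gave no change at the digits printed from compound 1 to compound 2 (within the scatter). Seen from the other direction, the swap of 3,5-dimethylbenzyl for 3-methoxyphenoxy gives a number 0.19 log units lower from compound 2 to compound 4 (within the scatter), the same size of step as a number 0.19 log units lower from compound 1 to compound 3 (within the scatter), so the two changes combine in these four compounds as the separate steps would suggest. That is one pair of cores, though, and every step lies within the scatter, so this shows that the change carried over without a visible effect, not that it would do so on any other core, and nothing measured here explains the result.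

The compounds shown leave open whether the read-out would stay as steady with a carboxylic acid or a dimethylamino group in place of furan-2-yl. They also leave open what a longer chain would do on either core.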